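A few compounds are considered here, and "the series" means these few. Any claim that something is new, unique, unknown or untested is made for them only; others in the source may bear on it.

Of the compounds shown here, three with a shared amide core have been measured in a functional assay on KYSE-410 cells (Homo sapiens) for antiproliferative activity, read by MTT assay, with a stated time of 72 h (a higher number here means a weaker inhibitor, a lower number a stronger inhibitor), and none of them reaches a potency of note. Compound 1 `O=C(Nc1ccc(Cl)cc1)c1ccnc2cc(Br)ccc12` gives only a limit of the assay, > 20000 nM. Among the measured compounds shown here, compound 2 `O=C(Nc1cc(F)cc(F)c1)c1cc(=O)[nH]c2cc(C(F)(F)F)ccc12` is the one member that returns a number, 17900 nM. Compound 3 `O=C(Nc1cccc(F)c1)c1cc(=O)[nH]c2cc(-c3ccccc3)ccc12`, carrying a phenyl on the shared core, also gives only a limit of the assay, > 20000 nM. For the measured compounds named here, compound 3 therefore stands where most of the set stands, since two of the three values sit at the limit of > 20000 nM in this assay, at which 2 of the 3 values shown sit, and no measured step from it to another compound can be drawn.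

Compound 4 `O=C(Nc1cccc(F)c1)c1cc(=O)[nH]c2cc(-c3ccncc3)ccc12` differs from compound 3 in one place: pyridin-4-yl in place of phenyl on an aromatic carbon. The pyridin-4-yl enters on an aromatic carbon of the fused ring system, meta to a fused ring and para to a fused ring. With no measured step of this kind in the set, no direction beyond the usual scatter of this assay is expected from compound 3 to compound 4. Compound 4 is accordingly estimated at 18000 nM, between 6000 nM and 50000 nM, in this assay, a change of an at least 1.1-fold lower number from compound 3 to compound 4 (0.04 log units; that floor lies within the scatter) from compound 3 that is expected to remain within the scatter, and it is judged likely that only a limit is reported again.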

Compound 4, half-maximal inhibitory concentration: > 20000 nM
Compound 4: no number, only a limit; the forecaster's own chance of this, stated with the estimate: 55%; middle value at least 1.1-fold (0.04 log units) away from the limit.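

Compound 3 and compound 4 both give only a limit, so the step between them cannot be read: the limit of > 20000 nM in this assay, at which 3 of the 4 values shown sit.

The compounds shown leave open whether pyridin-4-yl in place of phenyl changes the antiproliferative activity at all, and which change on the shared core would give a clear measured number.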